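The source may report more compounds than this note shows. Statements on the series, on what has been measured and on what is new or still open speak of the compounds shown alone.

Compound 3 `CCN(Cc1cccs1)C(=O)COc1ccc(Cl)cc1` stands lowest of the three numbers in an assay on HEK293 cells for agonist activity at transient receptor potential cation channel subfamily M member 8 (Homo sapiens), read by fluorescence and calcium flux, with a stated time of 15 min; on this read-out lower numbers stand for an effect already at smaller amounts and higher numbers for an effect only at larger amounts of compound: compound 3 gives 39 nM, while compound 1 `CCN(Cc1cccs1)C(=O)COc1ccc(F)cc1` gives 422 nM and compound 2 `CCCc1ccc(OCC(=O)N(CC)Cc2cccs2)cc1` gives 1810 nM. Compound 4 `CCN(Cc1cccs1)C(=O)COc1ccc(C#N)cc1` differs from compound 3 by cyano in place of chloro on an aromatic carbon. Among the compounds with values here, no measured pair exchanges chloro for cyano, so the steps that bear on it are the two that arrive at chloro: an 11-fold lower number from compound 1 to compound 3 (1.03 log units; beyond the scatter) and a 46-fold lower number from compound 2 to compound 3 (1.67 log units; beyond the scatter). Both were large and ran toward chloro, and a 4.3-fold higher number from compound 1 to compound 2 (0.63 log units; beyond the scatter) shows that a propyl at this carbon falls short of fluoro as well. Compound 4 is therefore expected to give a higher number, a 7.7-fold higher number from compound 3 to compound 4 (0.89 log units; beyond the scatter). For compound 4 the estimate in this assay is 300 nM, with a range from 60 nM to 1500 nM.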

Compound 4, half-maximal effective concentration: 1990 nM
Estimate against measurement, compound 4: 6.6-fold (0.82 log units) below; the measured number lies above the stated range.
By their numbers in this assay, from the lowest: compound 3; then compound 1; then compounds 2 and 4 (each within the scatter of the next).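

With cyano at this aromatic carbon, this assay gives a 51-fold higher number from compound 3 to compound 4 (1.71 log units; beyond the scatter) and also a 4.7-fold higher number from compound 1 to compound 4 (0.67 log units; beyond the scatter) in the comparison with fluoro, so the low number of compound 3 does not carry over to cyano. Against propyl, cyano gives a 1.1-fold higher number from compound 2 to compound 4 (0.04 log units; within the scatter) and no separation, which leaves chloro well apart from the other three groups. Nothing available explains why chloro stands apart. The compounds shown leave open whether bromo or methyl at this carbon would stay near chloro, and whether a second chloro elsewhere on the ring would change the number.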